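Hydroxy for methyl on the amine side chain

The compounds below may be only part of what the source reports. "The series", "measured", "known", "first", "only" and "open" are said of these compounds alone.

Three compounds of the shared core carry a measured number in a functional assay on SK-BR-3 cells (Homo sapiens) for antiproliferative activity; a lower number here means a stronger inhibitor, a higher number a weaker inhibitor. Compound 1 `CC(=O)Oc1ccc(C(=O)Nc2cc3ccc(OCC4CCN(C)C4)c(C)c3oc2=O)cc1CC=C(C)C` gives 880 nM in this assay. Compound 2 `CC(=O)Oc1ccc(C(=O)Nc2cc3ccc(OCC4CCCNC4)c(C)c3oc2=O)cc1CC=C(C)C` gives 620 nM. Compound 3 `CCCNCCCOc1ccc2cc(NC(=O)c3ccc(O)c(CC=C(C)C)c3)c(=O)oc2c1C` gives 990 nM. For the measured compounds named here, the one step between compounds that differ in a single place, a 1.4-fold lower number from compound 1 to compound 2 (0.15 log units; within the scatter), concerns the amine ring on the ether chain and stays within the scatter. Compound 3 therefore sits alongside compound 1 and compound 2: none of the three is set apart from the others by more than the scatter.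

Compound 4 `CC(C)=CCc1cc(C(=O)Nc2cc3ccc(OCCCNCCO)c(C)c3oc2=O)ccc1O` is the open-chain amine of compound 3 with one change: hydroxy in place of methyl on a saturated chain carbon, two bonds along the chain from an amine nitrogen. Going by the values given here, no measured step alters this chain at the carbon two bonds from the amine nitrogen, so the only guidance is the flat picture so far, in which a change on the amine side of the ether chain, from compound 1 to compound 2, moved nothing beyond the scatter. On that basis no step beyond the scatter is expected for compound 4, and its number in this assay is estimated at 900 nM, between 400 nM and 2000 nM, an expected step of a 1.1-fold lower number from compound 3 to compound 4 (0.04 log units; within the scatter).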

Compound 4, half-maximal inhibitory concentration: 610 nM
Estimate against measurement, compound 4: 1.5-fold (0.17 log units) above, within the range that was stated.
By their numbers in this assay, from the lowest: compounds 4, 2, 1 and 3 (each within the scatter of the next).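

In this assay, hydroxy in place of methyl on a saturated chain carbon, two bonds along the chain from an amine nitrogen, gives a 1.6-fold lower number from compound 3 to compound 4 (0.21 log units; within the scatter) and so leaves the number within the scatter. For the compounds shown here, this is the first reading on the open-chain amine itself: the earlier single change concerned only the amine ring on the ether chain, whereas propylamino to (2-hydroxyethyl)amino adds a hydrogen-bond donor and a hydrogen-bond acceptor at this carbon without a step beyond the scatter. No available measurement accounts for this result.

A carboxylic acid, a methoxy group or a primary amine in place of the hydroxy, or a longer chain such as 3-hydroxypropyl on the amine nitrogen, would test whether this flat reading holds beyond the single change shown here. The acetoxy group of compound 1 and compound 2 also remains unseparated from the free hydroxy of compound 3 and compound 4, as these pairs differ in the amine side chain as well.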